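Compound 4: dropping one chloro from compound 3

The compounds below may be only part of what the source reports. "The series", "measured", "known", "first", "only" and "open" are said of these compounds alone.

Values in a functional assay on A549 cells (Homo sapiens) for antiproliferative activity, read by MTT assay, with a stated time of 48 h; a higher number here means a weaker inhibitor, a lower number a stronger inhibitor:
compound 1 `COc1ccc(C(=O)/C=C/c2cccc(Cl)c2Oc2c([N+](=O)[O-])cc(C(F)(F)F)cc2[N+](=O)[O-])cc1`: 11.5 ug/mL
compound 2 `O=C(/C=C/c1cccc(Cl)c1Oc1c([N+](=O)[O-])cc(C(F)(F)F)cc1[N+](=O)[O-])c1ccc(F)cc1`: 23.8 ug/mL
compound 3 `O=C(/C=C/c1cc(Cl)cc(Cl)c1Oc1c([N+](=O)[O-])cc(C(F)(F)F)cc1[N+](=O)[O-])c1ccc(Cl)cc1`: 17.2 ug/mL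

Compound 3 stands within the scatter of both compound 1 and compound 2, so it cannot be ranked against either. The change to compound 4 `O=C(/C=C/c1cccc(Cl)c1Oc1c([N+](=O)[O-])cc(C(F)(F)F)cc1[N+](=O)[O-])c1ccc(Cl)cc1` is hydrogen in place of chloro on an aromatic carbon. For the measured compounds named here, the only measured step, a 2.1-fold higher number from compound 1 to compound 2 (0.32 log units; beyond the scatter), is modest and involves fluoro in place of methoxy at a different place. Going by the values given here, it therefore bears only loosely on this change, and no measured pair tests this chloro directly. No step beyond the scatter is expected in this assay. The expected step is a 1.0-fold lower number from compound 3 to compound 4 (0.01 log units; within the scatter). Compound 4 is estimated at 17 ug/mL, with an expected range of 9 ug/mL to 30 ug/mL.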

Compound 4, half-maximal inhibitory concentration: 11.7 ug/mL
Estimate against measurement, compound 4: 1.5-fold (0.16 log units) above, within the range that was stated.
By their numbers in this assay, from the lowest: compounds 1, 4, 3 and 2 (each within the scatter of the next, the first and the last beyond it).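

In this assay hydrogen in place of the chloro meta to the 2-((4-chlorophenyl)carbonyl)ethenyl group gives a 1.5-fold lower number from compound 3 to compound 4 (0.17 log units; within the scatter) and so shows no dependence on this chloro. On the other substituted ring, chloro in place of fluoro gives a 2.0-fold lower number from compound 2 to compound 4 (0.31 log units; beyond the scatter) while chloro in place of methoxy gives a 1.0-fold higher number from compound 1 to compound 4 (0.01 log units; within the scatter) so compound 2 stands apart from compound 1 and compound 4. Nothing here explains either result.

Still open, going by these compounds, is how this position responds to a group other than chloro or hydrogen, such as an amine or a carboxylic acid.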